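The source may report more compounds than this note shows. Statements on the series, on what has been measured and on what is new or still open speak of the compounds shown alone.

Of the compounds shown here, three built on one shared core have been measured in a functional assay on PC-3 cells (Homo sapiens) for inhibition, read by MTT assay, with a stated time of 48 h; on this read-out lower numbers stand for stronger inhibition and higher numbers for weaker inhibition. Compound 1 `C=C1CC[C@@H]2[C@](C)(CO)[C@H](O)CC[C@@]2(C)[C@@H]1CC(Sc1ccc(C)cc1)C1=CCOC1=O` gives 29000 nM, compound 2 `C=C1CC[C@@H]2[C@](C)(CO)[C@H](O)CC[C@@]2(C)[C@@H]1CC(Sc1ccc([N+](=O)[O-])cc1)C1=CCOC1=O` gives 17000 nM, and compound 3 `C=C1CC[C@@H]2[C@](C)(CO)[C@H](O)CC[C@@]2(C)[C@@H]1CC(Sc1ccc(OC)cc1)C1=CCOC1=O` gives 15000 nM. Compound 2 sits alongside the other two, with all three numbers inside the scatter of one another: a 1.7-fold lower number from compound 1 to compound 2 (0.23 log units; within the scatter), a 1.9-fold lower number from compound 1 to compound 3 (0.29 log units; within the scatter), and a 1.1-fold lower number from compound 2 to compound 3 (0.05 log units; within the scatter). Compound 4 `C=C1CC[C@@H]2[C@](C)(CO)[C@H](O)CC[C@@]2(C)[C@@H]1CC(Sc1ncccn1)C1=CCOC1=O` differs from compound 2 in one place: pyrimidin-2-yl in place of 4-nitrophenyl on a sulfur. Within the data shown here, each measured step so far swaps only a substituent on an aromatic carbon of the 4-nitrophenyl group, whereas this change replaces the whole 4-nitrophenyl with pyrimidin-2-yl on the sulfur, so none of the measured steps bears directly on it. What they do show is that the three variations at this part of the molecule have all stayed within the scatter, so no step beyond the scatter is expected in this assay, though the uncertainty is wide. Compound 4 is therefore estimated at 17000 nM, in a range from 6000 nM to 50000 nM. The expected step is no change at the digits printed from compound 2 to compound 4 (within the scatter).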

Compound 4, half-maximal inhibitory concentration: 7000 nM
Compound 4: the middle estimate sits 2.4-fold (0.39 log units) above what was measured, and the stated range covers the measured number.
By their numbers in this assay, from the lowest: compound 4; then compounds 3, 2 and 1 (each within the scatter of the next).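

In this assay, the group on the sulfur moved the number beyond the scatter, which the three substituent swaps on the aromatic carbon had not done: pyrimidin-2-yl brings a 2.4-fold lower number from compound 2 to compound 4 (0.39 log units; beyond the scatter), a 2.1-fold lower number from compound 3 to compound 4 (0.33 log units; beyond the scatter) and a 4.1-fold lower number from compound 1 to compound 4 (0.62 log units; beyond the scatter). All three steps are modest, yet they set compound 4 apart from the other three compounds, which stay within the scatter of one another where each step is printed. Nothing available explains this gain.

The compounds shown leave open whether the shift follows from the hetero atoms of the ring or from the loss of the substituent, which an unsubstituted phenyl or a pyridin-2-yl on the sulfur would help to separate. They also leave open whether an amine on the pyrimidin-2-yl, or a longer chain in its place, would move the number further.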